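The source may report more compounds than this note shows. Statements on the series, on what has been measured and on what is new or still open speak of the compounds shown alone.

In a functional assay on SEM cells (Homo sapiens) for cytotoxicity, with a stated time of 72 h (on this read-out lower numbers stand for an effect already at smaller amounts and higher numbers for an effect only at larger amounts of compound), compound 1 `C=C[C@@](C)(/C=C/c1ccc(O)cc1)CCC1OC1(C)C` gives only a limit, > 36600 nM. Compound 2 `C=C[C@@](C)(/C=C/c1ccc(O)cc1)CC/C=C/C(=O)OCC` also gives only a limit, > 36600 nM. For the measured compounds named here, compound 3 `C=C[C@@](C)(/C=C/c1ccc(O)c(C=O)c1)CCC=C(C)C` gives 8510 nM, the only true number so far, while the others sit at the limit of > 36600 nM in this assay, at which 2 of the 3 values shown sit. Compound 4 `C=C[C@@](C)(/C=C/c1ccc(O)c(/C=C/C#N)c1)CCC=C(C)C` differs from compound 3 by 2-cyanoethenyl in place of formyl on an aromatic carbon, with 2-cyanoethenyl in place of formyl on an aromatic carbon. Going by the values given here, the one measured step, a step that the two limits leave unreadable from compound 1 to compound 2, lies elsewhere in the molecule and has no readable size, so it offers nothing to carry over. With no guide to direction, no change beyond the scatter is expected in this assay, and the expected step is a 1.0-fold lower number from compound 3 to compound 4 (0.00 log units; within the scatter). For compound 4 the estimate is 8500 nM, with an expected range of 2500 nM to 30000 nM.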

Compound 4, half-maximal effective concentration: > 36600 nM
Compound 4 ended at the assay's limit; the forecaster's own chance of this, stated with the estimate: 20%; at least 4.3-fold (0.63 log units) between middle value and limit.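

In this assay, for the compounds shown here, the swap of formyl for 2-cyanoethenyl on an aromatic carbon ortho to a hydroxy group gives the first step of readable size, an at least 4.3-fold higher number from compound 3 to compound 4 (0.63 log units; beyond the scatter). This shows that the group at this position matters, and that this change loses effect. Going by these compounds alone, the full size of the loss stays unknown, and compound 3 remains the only compound with a true number: the limit of > 36600 nM in this assay, at which 3 of the 4 values shown sit.

From the compounds shown here alone, whether an amine or a carboxylic acid at this position would match compound 3 stays open. So does whether formyl itself is needed for the effect.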